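Varying the substituent on the aromatic nitrogen of the shared core

A few compounds are considered here, and "the series" means these few. Any claim that something is new, unique, unknown or untested is made for them only; others in the source may bear on it.

The measured compounds are:
compound 1 `CCc1nc2c(-c3ccc(Cl)cc3Cl)ccnc2n1[C@@H](CC)C1CC1`, 0.4 nM;
compound 2 `CCc1nc2c(-c3ccc(Cl)cc3Cl)ccnc2n1[C@H](C)C1CC1`, 0.6 nM;
compound 3 `CCCC(C)n1c(CC)nc2c(-c3ccc(Cl)cc3Cl)ccnc21`, 0.5 nM.

All three were measured in an assay for binding affinity to Corticotropin releasing factor receptor (Rattus norvegicus); a higher number here means a weaker inhibitor, a lower number a stronger inhibitor. Compound 3 stands second highest of the three numbers, within the scatter of both neighbours: the step of a 1.3-fold higher number from compound 1 to compound 3 (0.10 log units; within the scatter) and the step of a 1.2-fold lower number from compound 2 to compound 3 (0.08 log units; within the scatter) are both small. Compound 4 `CCc1nc2c(-c3ccc(Cl)cc3Cl)ccnc2n1C(CCOC)C1CCC1` differs from compound 3 by 1-cyclobutyl-3-methoxypropyl in place of 1-methylbutyl on an aromatic nitrogen. The two steps that bear on this change, from compound 1 to compound 3 and from compound 2 to compound 3, each swapped the group on the aromatic nitrogen and each stayed within the scatter. A step of similar size is therefore expected here, a 1.6-fold higher number from compound 3 to compound 4 (0.20 log units; within the scatter), with no direction beyond the scatter. Compound 4 is estimated at 0.8 nM, with a range from 0.3 nM to 2.5 nM.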

Compound 4, inhibition constant: 2.4 nM
Estimate against measurement, compound 4: 3.0-fold (0.48 log units) below; low and high end bracket the measured number.
By their numbers in this assay, from the lowest: compounds 1, 3 and 2 (each within the scatter of the next); then compound 4.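

Until now, swaps of the group on the aromatic nitrogen had stayed within the scatter in this assay, but 1-cyclobutyl-3-methoxypropyl moves the number beyond it against all three earlier groups (a 4.8-fold higher number from compound 3 to compound 4 (0.68 log units; beyond the scatter)) and (a 4.0-fold higher number from compound 2 to compound 4 (0.60 log units; beyond the scatter)) and (a 6.0-fold higher number from compound 1 to compound 4 (0.78 log units; beyond the scatter)). This position therefore does not take every group alike, and the change here adds a four-membered ring and a hydrogen-bond acceptor and goes from 5 heavy atoms to 9. Nothing available explains why the number rises.

The compounds shown leave open which part of the entering group goes with the higher number, the cyclobutyl ring or the methoxy end of the chain. Also open, on these data alone, is how an amine or a carboxylic acid at the end of that chain would read.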